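The compounds below may be only part of what the source reports. "The series", "measured", "known", "first", "only" and "open" are said of these compounds alone.

Four compounds share a core from which a benzyl ether hangs. Compound 1 `CC(C)C1C(=O)Nc2ccc(OCc3cccc(F)c3)cc21` has a different core from the others and a fluoro group on its benzyl ring; in an assay on cells for inhibition of Amine oxidase [flavin-containing] B (Homo sapiens), read by fluorescence, with stated times of 30 min and 15 min (on this read-out higher numbers stand for weaker inhibition and lower numbers for stronger inhibition), compound 1 gives 397000 nM. Compound 2 `Cn1c(=O)[nH]c2cc(OCc3cccc(Cl)c3)ccc21` carries one chloro group on the benzyl ring, and in this assay compound 2 gives 34300 nM. Compound 3 `Cn1c(=O)[nH]c2ccc(OCc3ccc(Cl)cc3)cc21` also carries one chloro group on the benzyl ring, and in this assay compound 3 gives 56400 nM. Among these three numbers compound 3 stands second highest: its number lies close to that of compound 2, within the usual scatter, while compound 1 gives a clearly higher number, beyond the scatter.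

Compound 4 `Cn1c(=O)[nH]c2ccc(OCc3ccc(Cl)c(Cl)c3)cc21` differs from compound 3 by chloro in place of hydrogen on an aromatic carbon. Among the measured compounds shown here, no measured pair here shows such a step, so the expectation rests on the gathered numbers alone. The expected step of a 2.8-fold lower number from compound 3 to compound 4 (0.45 log units; beyond the scatter) is a modest move toward stronger inhibition, small enough that it may fall within the scatter. Compound 4 is therefore estimated at 20000 nM, within a range from 5000 nM to 80000 nM.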

Compound 4, half-maximal inhibitory concentration: 7680 nM
Compound 4: the middle estimate sits 2.6-fold (0.42 log units) above what was measured, within the range that was stated.
By their numbers in this assay, from the lowest: compound 4; then compounds 2 and 3 (each within the scatter of the next); then compound 1.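

In this assay, placing a second chloro group on the benzyl ring gives a 7.3-fold lower number from compound 3 to compound 4 (0.87 log units; beyond the scatter), a step beyond the usual scatter and toward stronger inhibition. Among the compounds shown here, this is the only pair here that differs in one place, and it shows that on this core, hydrogen can be replaced with chloro at this aromatic carbon, ortho to a chloro group and meta to a large group, with stronger inhibition as the result. No available measurement bears on the reason for the size of this step.

From the compounds shown here alone, whether this result is specific to chloro remains open, since a methyl group, a methoxy group or a trifluoromethyl group at the same carbon could behave differently. Going by these compounds, it is also open whether this chloro group would give a similar step without the chloro group already present on the ring of compound 3.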